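From 2-chlorophenyl to 4-fluorophenyl in a growth assay

A few compounds are considered here, and "the series" means these few. Any claim that something is new, unique, unknown or untested is made for them only; others in the source may bear on it.

In a functional assay on HCT-116 cells (Homo sapiens) for inhibition, read by sulforhodamine B assay, with a stated time of 3 days (a higher number here means a weaker inhibitor of growth, a lower number a stronger inhibitor of growth), compound 1 `O=C(/C=C/c1ccccc1Cl)c1ccc(OCc2ccccc2)cc1` gives 14900 nM while compound 3 `O=C(/C=C/c1ccc(Cl)cc1)c1ccccc1` gives 16500 nM as its value, two numbers within the scatter of each other and the only exact ones so far. Compound 2 `COc1ccc(CCC(=O)c2ccccc2)cc1` shows > 100000 nM as a limit and not as a number. Compound 4 `O=C(/C=C/c1ccc(F)cc1)c1ccc(OCc2ccccc2)cc1` has 4-fluorophenyl in place of 2-chlorophenyl on a double-bonded chain carbon bound to a double-bonded chain carbon in its structure. Among the measured compounds shown here, no measured pair shows this swap alone. Compound 3 at 16500 nM stays close to compound 1 at 14900 nM despite their different structures, so a large move seems unlikely. The step of a 1.2-fold lower number from compound 1 to compound 4 (0.09 log units; within the scatter) is expected to stay within the scatter. For compound 4 12000 nM is the estimated value, with 5000 nM to 30000 nM as its expected range.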

Compound 4, concentration for 50% growth inhibition: > 50000 nM
Compound 4: no number, only a limit; the forecaster's own chance of this, stated with the estimate: 3%; middle value at least 4.1-fold (0.61 log units) away from the limit.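

In this assay, this place on a double-bonded chain carbon bound to a double-bonded chain carbon proves sensitive: 4-fluorophenyl in place of 2-chlorophenyl gives an at least 3.3-fold higher number from compound 1 to compound 4 (0.52 log units; beyond the scatter). Among the compounds shown here, this is the first change in a single place here, and it moves the number beyond the scatter while the rest of the core of compound 1 stays the same. The full size of the step stays unknown because compound 4 has only a limit and not a number: the limit of > 50000 nM in this assay, at which 1 of the 4 values shown sits.

Going by these compounds, the swap changes both the halogen and its ring numbering at once, so it remains open which of the two matters. On the core of compound 1, 2-fluorophenyl or 4-chlorophenyl would separate them.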